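Urea in Place of Amide on a Shared Pyrazole Core

A few compounds are considered here, and "the series" means these few. Any claim that something is new, unique, unknown or untested is made for them only; others in the source may bear on it.

Compound 1, `COc1cc(-c2nn(-c3cccc(NC(=O)Nc4cc(C(F)(F)F)cc(C(F)(F)F)c4)c3)cc2-c2ccncc2)ccc1Cl`, gives 617 nM in a functional assay on HCT-15 cells (Homo sapiens) for inhibition, read by sulforhodamine B assay, with a stated time of 48 h; a lower number here means a stronger inhibitor of growth, a higher number a weaker inhibitor of growth.
Compound 2, `COc1cc(-c2nn(-c3cccc(NC(=O)c4cccc(C(F)(F)F)c4)c3)cc2-c2ccncc2)ccc1Cl`, gives 1550 nM in this assay.
Compound 3, `O=C(Nc1cccc(-n2cc(-c3ccncc3)c(-c3ccc(Cl)c(O)c3)n2)c1)Nc1ccc(Cl)c(Cl)c1`, gives 1230 nM in this assay.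

Compound 2 stands at the highest of the three numbers. Its gap to compound 3 lies within the scatter; its gap to compound 1 lies beyond it, so compound 2 is a weaker growth inhibitor than compound 1.

Compound 4, `COc1cc(-c2nn(-c3cccc(NC(=O)Nc4cccc(C(F)(F)F)c4)c3)cc2-c2ccncc2)ccc1Cl`, differs from compound 2 in one place: (3-(trifluoromethyl)phenyl)amino in place of 3-(trifluoromethyl)phenyl on a carbonyl carbon. Among the compounds with values here, no measured pair shows this same change, so its effect is uncertain. Compound 1 also carries a urea and gives 617 nM, which suggests the step from compound 2 to compound 4 may lower the number somewhat, though not necessarily beyond the scatter. The expected step is a 1.7-fold lower number from compound 2 to compound 4 (0.24 log units; within the scatter). Compound 4 is estimated at 900 nM, within a range from 400 nM to 2000 nM.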

Compound 4, concentration for 50% growth inhibition: 870 nM
Compound 4: the middle estimate sits 1.0-fold (0.01 log units) above what was measured; the range from low to high includes it.
By their numbers in this assay, from the lowest: compounds 1, 4, 3 and 2 (each within the scatter of the next, the first and the last beyond it).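

Within the data shown here, compound 4 gives the first reading of (3-(trifluoromethyl)phenyl)amino in place of 3-(trifluoromethyl)phenyl on a carbonyl carbon: in this assay the change comes with a 1.8-fold lower number from compound 2 to compound 4 (0.25 log units; within the scatter), so urea and amide are not told apart here. Hydrogen in place of trifluoromethyl on an aromatic carbon comes with a 1.4-fold higher number from compound 1 to compound 4 (0.15 log units; within the scatter), so that trifluoromethyl is not shown to matter either. No measurement shown explains these small steps.

From the compounds shown here alone, it remains open whether a cyclohexylamino or a methylamino group on that carbonyl carbon would give a step beyond the scatter.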